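The source may hold more compounds than are shown below. What is called first, only, known or untested is meant among the compounds shown, and "the series" means these compounds.

Compounds with a value so far:

compound 1 `COc1ccc2c(c1)NC(=O)CN2c1nc(OCC2CC2)nc2ccccc12` — 7.88 nM
compound 2 `COc1ccc2c(c1)NC(=O)CN2c1nc(COCCCC(=O)NO)nc2ccccc12` — 1210 nM
compound 3 `COc1ccc2c(c1)NC(=O)CN2c1nc(N2CCCC2)nc2ccccc12` — "not determined" (no result reported)

Going by the values given here, in a functional assay on MCF7 cells (Homo sapiens) for inhibition, read by sulforhodamine B assay, with a stated time of 48 h (a higher number here means a weaker inhibitor of growth, a lower number a stronger inhibitor of growth), compound 1 gives 7.88 nM, whereas compound 2 gives 1210 nM; the single measured step is a 150-fold higher number from compound 1 to compound 2 (2.19 log units; beyond the scatter), the only change being the group on the aromatic carbon of the shared core. Compound 3, which carries pyrrolidin-1-yl at the same place, gives "not determined" (no result reported) in this assay, so it stands nowhere on the scale shown and there is no measured step leading from it.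

Compound 4 `COc1ccc2c(c1)NC(=O)CN2c1nc(N2CC(OC)C2)nc2ccccc12` differs from compound 3 as follows: 3-methoxyazetidin-1-yl in place of pyrrolidin-1-yl on an aromatic carbon. Among the compounds with values here, no measured step covers an exchange of one such ring amine for another; the step from compound 1 to compound 2 concerns quite different groups at that carbon and shows only that this position tolerates large swings. The estimate is therefore given with a wide range and set nearer to where compound 1 stands than to where compound 2 stands. In this assay the number for compound 4 is expected to be 40 nM, with an estimated range from 4 nM to 600 nM.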

Compound 4, concentration for 50% growth inhibition: 8.6 nM
Estimate against measurement, compound 4: 4.7-fold (0.67 log units) above, and the stated range covers the measured number.
By their numbers in this assay, from the lowest: compounds 1 and 4 (each within the scatter of the next); then compound 2.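

In this assay the two groups 3-methoxyazetidin-1-yl and cyclopropylmethoxy on the aromatic carbon between two ring nitrogen atoms cannot be told apart (a 1.1-fold higher number from compound 1 to compound 4 (0.04 log units; within the scatter)), so at this carbon a group attached through a ring nitrogen matches one attached through an ether oxygen. The weak result for (3-(hydroxycarbamoyl)propoxy)methyl now stands apart from two different groups and not just one (a 140-fold lower number from compound 2 to compound 4 (2.15 log units; beyond the scatter)), which makes it a feature of that group and not of the position. Nothing measured here accounts for either step.

The exchange of pyrrolidin-1-yl for 3-methoxyazetidin-1-yl cannot be read, as compound 3 has no value. Also open, as far as these compounds go, is where azetidin-1-yl without the methoxy, or an open-chain amine such as dimethylamino, would stand at this carbon.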